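The compounds below may be only part of what the source reports. "The series", "measured", "known", "first", "only" and "open" are said of these compounds alone.

In a functional assay on the whole organism for inhibition, with Rattus norvegicus as the target (on this read-out higher numbers stand for an effect only at larger amounts of compound and lower numbers for an effect already at smaller amounts), compound 1 `COc1ccccc1CC(Oc1ccc(C(C)C)cc1)C(=O)O` gives > 10 mg/kg, which is a limit of the assay and not a number. Among the measured compounds shown here, compound 2 `CC(C)c1ccc(OC(C)(Cc2cccc(C(F)(F)F)c2)C(=O)O)cc1` gives 5 mg/kg, the only actual number so far, so it has no measured neighbour to be ranked against. Compound 3 `CC(C)c1ccc(OC(C)(Cc2cccc(-c3ccccc3)c2)C(=O)O)cc1` keeps the rest of compound 2 and changes one group: phenyl in place of trifluoromethyl on an aromatic carbon. For the measured compounds named here, no measured step shows what such a swap does. The expected step of a 1.4-fold higher number from compound 2 to compound 3 (0.15 log units; within the scatter) is therefore small, within the usual scatter, and leans slightly toward a larger dose. In this assay the estimated dose for compound 3 is 7 mg/kg, with an expected range of 2.5 mg/kg to 20 mg/kg.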

Compound 3, dose for half-maximal effect: 0.5 mg/kg
The estimate for compound 3 lay 14-fold (1.15 log units) above the measured number; the whole stated range lies above it.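

At this aromatic carbon, the first measured change shows that phenyl in place of trifluoromethyl gives a 10-fold lower number from compound 2 to compound 3 (1.00 log units; beyond the scatter) in this assay. The position therefore accepts a larger group, an aromatic ring, and here the effect appears at a smaller dose, though this rests on a single pair. Compound 1 adds no step here, as its value is a limit and not a number: the limit of > 10 mg/kg in this assay, at which 1 of the 3 values shown sits.

Open, from the compounds shown here alone, is what a methyl group, a chlorine atom or a phenyl ring carrying an amine would do at this place. One pair also cannot tell whether the gain comes from the phenyl arriving or the trifluoromethyl leaving.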